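From ethylsulfanyl to tert-butyl on the shared core

The source may report more compounds than this note shows. Statements on the series, on what has been measured and on what is new or still open speak of the compounds shown alone.

compound 1 `CCSc1ccc(-c2nccc3[nH]c(C(C)(C)O)cc23)cc1`: 17200 nM
compound 2 `CC(C)(O)c1cc2c(-c3ccccc3CO)nccc2[nH]1`: "not determined" (no result reported)

Among the measured compounds shown here, in an ADME assay on U2OS cells (Homo sapiens) for cytotoxicity (on this read-out lower numbers stand for higher toxicity in this test and higher numbers for lower toxicity in this test), compound 1 gives 17200 nM, the only number available, so it cannot yet be ranked against any other compound. Compound 3 `CC(C)(C)c1ccc(-c2nccc3[nH]c(C(C)(C)O)cc23)cc1` carries tert-butyl in place of ethylsulfanyl on an aromatic carbon. For the measured compounds named here, no measured pair shows what such a swap does, so no step beyond the usual scatter is expected in this assay, and no direction is favoured. The expected result is a 1.1-fold lower number from compound 1 to compound 3 (0.06 log units; within the scatter). Compound 3 is estimated at 15000 nM, within an expected range of 6000 nM to 40000 nM.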

Compound 3, half-maximal cytotoxic concentration: 35300 nM
Compound 3: the middle estimate sits 2.4-fold (0.37 log units) below what was measured; measured number inside the range.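

In this assay tert-butyl in place of ethylsulfanyl brings a 2.1-fold higher number from compound 1 to compound 3 (0.31 log units; beyond the scatter) and so points toward lower toxicity in this test, which shows that the group at this position can move the number. This is a modest step and rests on a single pair of compounds. Nothing measured here explains the change. Among the compounds shown here, compound 2 has no number, so no step to it can be read. As far as these compounds go, whether an amine, a carboxylic acid or a longer chain at this position would move the number further, or the other way, remains open.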